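This account rests on a few compounds, and the source may have more. Where it says the series, first, only, none or still open, it means among the compounds named here.

Measured so far in an ADME assay on MT4 cells (Homo sapiens) for inhibition, read by MTT assay, with a stated time of 5 days; a higher number here means that more compound is tolerated, a lower number that less compound is tolerated:
- compound 1 `Cc1cccc(C)c1Oc1cc(Nc2ccc(C#N)cc2)ncc1[N+](=O)[O-]`: 126000 nM
- compound 2 `Cc1cc(C)c(Oc2cc(Nc3ccc(C#N)cc3)ncc2[N+](=O)[O-])c(C)c1`: 69900 nM
- compound 3 `Cc1cc(Br)cc(C)c1Oc1cc(Nc2ccc(C#N)cc2)ncc1[N+](=O)[O-]`: 12300 nM

Compound 3 has the lowest of the three numbers, at 12300 nM. Both of its steps lie beyond the scatter: a 10-fold lower number from compound 1 to compound 3 (1.01 log units; beyond the scatter), and a 5.7-fold lower number from compound 2 to compound 3 (0.75 log units; beyond the scatter). By contrast, a 1.8-fold lower number from compound 1 to compound 2 (0.26 log units; within the scatter) stays within the scatter.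

The next compound is compound 4 `Cc1cc(Cl)cc(C)c1Oc1cc(Nc2ccc(C#N)cc2)ncc1[N+](=O)[O-]`, with chloro in place of bromo on an aromatic carbon, meta to two methyl groups and para to a large group: chloro in place of bromo on an aromatic carbon. Within the data shown here, no measured step exchanges one halogen for another, and no measured compound carries chloro, so the evidence is indirect. The two steps that introduce bromo at this place, a 10-fold lower number from compound 1 to compound 3 (1.01 log units; beyond the scatter) and a 5.7-fold lower number from compound 2 to compound 3 (0.75 log units; beyond the scatter), bound the likely outcome. Compound 4 is expected to remain closer to compound 3 than to compound 2 in this assay, with a small shift towards a higher number. The expected move is a 1.6-fold higher number from compound 3 to compound 4 (0.21 log units; within the scatter), which would probably not clear the scatter. For compound 4 the estimated value is 20000 nM, with an expected range of 9000 nM to 55000 nM.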

Compound 4, half-maximal cytotoxic concentration: 11100 nM
The estimate for compound 4 lay 1.8-fold (0.26 log units) above the measured number, and the stated range covers the measured number.
By their numbers in this assay, from the lowest: compounds 4 and 3 (each within the scatter of the next); then compounds 2 and 1 (each within the scatter of the next).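

In this assay, the exchange of bromo for chloro on this aromatic carbon, para to a large group, gives no readable change (a 1.1-fold lower number from compound 3 to compound 4 (0.04 log units; within the scatter)), so the two halogens are not separated here. The low number seen with compound 3 is therefore not peculiar to bromo: chloro also stands clearly apart from methyl (a 6.3-fold lower number from compound 2 to compound 4 (0.80 log units; beyond the scatter)) and further still from hydrogen (an 11-fold lower number from compound 1 to compound 4 (1.06 log units; beyond the scatter)), and among the compounds shown the 4-bromo-2,6-dimethylphenyl and 4-chloro-2,6-dimethylphenyl groups form one low pair, with compound 2 and compound 1 as a higher pair. No measurement in hand accounts for this split between the halogens and the other two substituents.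

On these data alone, it remains open whether the same low number extends to fluoro or iodo at this place, or whether it is confined to chloro and bromo. Also unsettled is where a methoxy group, an amine or a carboxylic acid on this carbon would fall relative to these two pairs, and whether the halogen step would hold with the rest of the core changed.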